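Chain length on the core of compound 2

This account rests on a few compounds, and the source may have more. Where it says the series, first, only, none or still open, it means among the compounds named here.

Measured so far:
compound 1 `O=C(O)c1cc2cc(S(=O)(=O)NCc3ccccc3)ccc2n1Cc1ccccc1`: 42%
compound 2 `O=C(O)c1cc2cc([N+](=O)[O-])ccc2n1CCCCCc1ccccc1`: 58%

In an assay on cells (Oocyte) for inhibition of pannexin-1 (Mus musculus), read by voltage clamp, tested at 50 uM, in the presence of a further agent that is not named here (on this read-out higher numbers stand for more inhibition at the one concentration tested (going by the name of the read-out) and lower numbers for less inhibition), compound 2 gives 58%, the higher of the two numbers; compound 1 gives 42%, and the gap between the two lies beyond the usual scatter. Compound 3 `O=C(O)c1cc2cc([N+](=O)[O-])ccc2n1CCCCc1ccccc1` is the next step from compound 2, with the change (phenyl in place of benzyl on a saturated chain carbon, four bonds along the chain from an aromatic nitrogen). For the measured compounds named here, no pair of measured compounds shows this change, so the size of the step is not known from the numbers. A small step downward, not beyond the scatter, is expected for compound 3 as a number 6 percentage points lower from compound 2 to compound 3 (within the scatter). Compound 3 is estimated at 52%, in the range 35% to 70%.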

Compound 3, a percentage reported as inhibition, at one concentration (the size of the read-out at that concentration, not a potency): "not active" (no number reported)
Nothing numeric was reported for compound 3; no gap can be computed for the estimate.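

For the compounds shown here, compound 3 carries only the label "not active", with no number, so no step from compound 2 to compound 3 can be read. Nothing on hand explains this result. The compounds shown leave open how far the change from benzyl to phenyl on the chain moves inhibition.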